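Alkyne substituent variation on the shared core

This account rests on a few compounds, and the source may have more. Where it says the series, first, only, none or still open, it means among the compounds named here.

Compound 1 `CN[C@@H](C#Cc1c(F)ccc2c1/C(=C/c1[nH]ccc1OC)C(=O)N2)CO` gives 300 nM in a functional assay on MDA-MB-435 cells (Homo sapiens) for inhibition (a lower number here means a stronger inhibitor, a higher number a weaker inhibitor), the lowest of the three numbers, though its neighbours sit within the scatter of it. Compound 2 `CN[C@H](C#Cc1c(F)ccc2c1/C(=C/c1[nH]ccc1OC)C(=O)N2)CO` gives 349 nM in this assay; the pair is separated only by the fact that compounds 1 and 2 differ only in the configuration as drawn, and the step is a 1.2-fold higher number from compound 1 to compound 2 (0.07 log units; within the scatter). Compound 3 `COc1cc[nH]c1/C=C1\C(=O)Nc2ccc(F)c(C#CC3(O)CCOCC3)c21` gives 600 nM in this assay; it carries 4-hydroxyoxan-4-yl where compound 1 carries 2-hydroxy-1-(methylamino)ethyl on the triple-bonded carbon, and the step is a 2.0-fold higher number from compound 1 to compound 3 (0.30 log units; within the scatter), with a 1.7-fold higher number from compound 2 to compound 3 (0.24 log units; within the scatter) from compound 2.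

Compound 4 `COc1cc[nH]c1/C=C1\C(=O)Nc2ccc(F)c(C#C[C@@H]3C[C@@H](O)CN3)c21` is not yet measured. Relative to compound 1 the change is 4-hydroxypyrrolidin-2-yl in place of 2-hydroxy-1-(methylamino)ethyl on a triple-bonded carbon. Among the measured compounds shown here, the measured step that bears on it is the one to compound 3, a 2.0-fold higher number from compound 1 to compound 3 (0.30 log units; within the scatter), where a hydroxyl-bearing ring likewise replaced the open chain on the triple-bonded carbon and the number stayed within the scatter. A small move to a higher number in this assay is therefore expected for compound 4, a 1.4-fold higher number from compound 1 to compound 4 (0.15 log units; within the scatter). The estimate for compound 4 is 420 nM, with a range of 150 nM to 1200 nM.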

Compound 4, half-maximal inhibitory concentration: 63 nM
Beside the measured number, compound 4's estimate is 6.7-fold (0.82 log units) above it; measured number below the stated range.
By their numbers in this assay, from the lowest: compound 4; then compounds 1, 2 and 3 (each within the scatter of the next).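

Notes on the position on the triple-bonded carbon: in this assay, this position can carry a change beyond the scatter, since 4-hydroxypyrrolidin-2-yl in place of 2-hydroxy-1-(methylamino)ethyl gives a 4.8-fold lower number from compound 1 to compound 4 (0.68 log units; beyond the scatter) and a 5.5-fold lower number from compound 2 to compound 4 (0.74 log units; beyond the scatter). A hydroxyl-bearing ring alone does not go with the lower number: compound 3, with 4-hydroxyoxan-4-yl, goes against that reading, and exchanging that ring for 4-hydroxypyrrolidin-2-yl gives a 9.5-fold lower number from compound 3 to compound 4 (0.98 log units; beyond the scatter). Nothing available gives a cause for these steps.

Still open, as far as these compounds go, is whether the lower number depends on the hydroxyl, on the ring nitrogen or on the two defined stereocentres of 4-hydroxypyrrolidin-2-yl. A plain pyrrolidin-2-yl group, its opposite-configured isomers and a piperidin-2-yl ring would help to separate these.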